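The source may hold more compounds than are shown below. What is called first, only, known or untested is meant among the compounds shown, and "the series" means these compounds.

Measured in a functional assay on SW-620 cells (Homo sapiens) for inhibition, read by sulforhodamine B assay, with a stated time of 48 h; on this read-out lower numbers stand for stronger inhibition of growth and higher numbers for weaker inhibition of growth:
- compound 1 `Cc1ccc(C2=NN(c3ccc(S(C)(=O)=O)cc3)C(=O)CC2)cc1`: 340 nM
- compound 2 `Cc1cc(O)ccc1C1=NN(c2ccc(S(C)(=O)=O)cc2)C(=O)CC1`: 3320 nM

Compound 2 has the higher of the two numbers, so it is the weaker growth inhibitor of the pair. The next compound to consider is compound 3 `CCc1ccc(C2=NN(c3ccc(S(C)(=O)=O)cc3)C(=O)CC2)cc1`, with 4-ethylphenyl in place of 4-hydroxy-2-methylphenyl on a carbon with a double bond to nitrogen.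

Among the measured compounds shown here, one measured step bears on this change: a 9.8-fold higher number from compound 1 to compound 2 (0.99 log units; beyond the scatter), which brought in the same 4-hydroxy-2-methylphenyl group in place of 4-methylphenyl. Compound 3 gives that group up again, so a step of similar size in the opposite direction is expected in this assay, although a single step is thin support. The expected change is a 7.9-fold lower number from compound 2 to compound 3 (0.90 log units; beyond the scatter). For compound 3 the estimated value is 420 nM, with an expected range of 150 nM to 1200 nM.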

Compound 3, concentration for 50% growth inhibition: 43100 nM
Estimate against measurement, compound 3: 100-fold (2.01 log units) below, and the stated range ends below it.
By their numbers in this assay, from the lowest: compound 1; then compound 2; then compound 3.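

Working notes on the position on the carbon with a double bond to nitrogen: in this assay, lengthening 4-methylphenyl by one carbon to 4-ethylphenyl gives a 130-fold higher number from compound 1 to compound 3 (2.10 log units; beyond the scatter), so this position responds sharply to a small change in the hydrocarbon group alone. Giving up 4-hydroxy-2-methylphenyl does not bring back the value of compound 1, since 4-ethylphenyl in its place gives a 13-fold higher number from compound 2 to compound 3 (1.11 log units; beyond the scatter), and the hydroxy-bearing group therefore ranks between 4-methylphenyl and 4-ethylphenyl rather than last. No measurement offered here accounts for this order.

Open, from the compounds shown here alone, is whether a longer chain such as propyl or a branched one such as isopropyl would follow 4-ethylphenyl at this position. Also open, going by these compounds, is how a methoxy group, a halogen such as chlorine, or an amine would rank there against 4-methylphenyl.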